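Methoxy addition across two chalcone-type cores

A few compounds are considered here, and "the series" means these few. Any claim that something is new, unique, unknown or untested is made for them only; others in the source may bear on it.

The series comprises compound 1 `C=C(Br)C(=O)Nc1ccc(C(=O)/C=C/c2cccc(OC)c2OC)cc1`, compound 2 `C=C(Br)C(=O)Nc1ccc(C(=O)/C=C/c2ccc(OC)c(OC)c2OC)cc1`, compound 3 `COc1ccc(/C=C/C(=O)c2ccc(N)cc2)c(OC)c1` and the as yet unmeasured compound 4 `COc1ccc(/C=C/C(=O)c2ccc(N)cc2)c(OC)c1OC`. In a functional assay on L1210 cells (Mus musculus) for antiproliferative activity, with a stated time of 48 h (on this read-out lower numbers stand for stronger inhibition and higher numbers for weaker inhibition), compound 1 gives 1100 nM, compound 2 gives 630 nM and compound 3 gives 34000 nM. The difference between the core of compound 1 and the core of compound 3 is not broken down here; the two values show compound 3 far weaker than either of the other two measured compounds.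

The step from compound 1 to compound 2 is a methoxy in place of hydrogen on an aromatic carbon, (methoxy in place of hydrogen on an aromatic carbon), and it produced a 1.7-fold lower number from compound 1 to compound 2 (0.24 log units; within the scatter). The change from compound 3 to compound 4, (methoxy in place of hydrogen on an aromatic carbon), is the same kind of change, but not the same: in compound 2 the entering methoxy sits ortho to a methoxy group, meta to a methoxy group and para to a large group, whereas in compound 4 it sits ortho to two methoxy groups and meta to a large group.

For the measured compounds named here, with only one precedent, and that one within the scatter, the expectation for compound 4 in this assay rests on compound 3 giving 34000 nM and on the earlier step being small; a step of about a 1.5-fold lower number from compound 3 to compound 4 (0.19 log units; within the scatter) is expected. Compound 4 is therefore estimated at 22000 nM, with a plausible range from 8000 nM to 60000 nM.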

Compound 4, half-maximal inhibitory concentration: 25000 nM
For compound 4 the middle estimate is 1.1-fold (0.06 log units) below the measured one, and the stated range covers the measured number.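

In this assay the methoxy change gives a 1.4-fold lower number from compound 3 to compound 4 (0.13 log units; within the scatter), and the step reads the same on the two cores: the same change on two cores in this assay, a 1.7-fold lower number (0.24 log units; within the scatter) from compound 1 to compound 2 and a 1.4-fold lower number (0.13 log units; within the scatter) from compound 3 to compound 4, 1.3-fold (0.11 log units) apart, within the scatter of two such steps

Within these two pairs, the change therefore carries from one core to the other as a small step that stays inside the scatter, but neither pair shows that the methoxy itself moves the number, and two pairs say nothing about further cores or other places on the ring.

For the compounds shown here, the one large step in this set lies on the nitrogen rather than on the ring: with hydrogen in place of (1-bromoethenyl)carbonyl there is a 40-fold higher number from compound 2 to compound 4 (1.60 log units; beyond the scatter), which shows how much this single replacement matters in the trimethoxy series, but not which part of the (1-bromoethenyl)carbonyl group accounts for it.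

The compounds shown leave open whether an ethoxy or a hydroxy in place of the entering methoxy would also give a step within the scatter on both cores. They also leave open how a simple acetyl or a chloroacetyl on the nitrogen would compare with the (1-bromoethenyl)carbonyl group and with hydrogen.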